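The compounds below may be only part of what the source reports. "The series", "measured", "known", "first", "only" and "open" are said of these compounds alone.

Measured in a physicochemical assay for acid dissociation:
- compound 1 `COc1ccc(Oc2ccc3c(NCCCNCc4cc(F)ccc4OC)ccnc3c2)cc1`: 9.28
- compound 2 `c1ccc(-c2ccc3c(NCCCNCc4ccco4)ccnc3c2)cc1`: 9.47
- compound 3 `COc1ccc(F)cc1CNCCCNc1ccnc2cc(C3CCCCC3)ccc12`: 9.47

Compound 3 stands level with compound 2 at the digits given; together they hold the highest of the three numbers, while compound 1 sits lowest, with the whole spread within the scatter. Going by the values given here, only one measured step touches the position varied here: a number 0.19 log units higher from compound 1 to compound 3 (within the scatter), which is within the scatter, so swapping a cyclohexyl for an aryl ether at this carbon has not moved the read-out beyond noise.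

Compound 4 `COc1cccc(Oc2ccc3c(NCCCNCc4cc(F)ccc4OC)ccnc3c2)c1` differs from compound 3 as follows: 3-methoxyphenoxy in place of cyclohexyl on an aromatic carbon. Compound 1 already carries a methoxyphenoxy at this same position and gives 9.28, so no shift beyond the scatter is expected in this assay. For compound 4 the step expected is a number 0.14 log units lower from compound 3 to compound 4 (within the scatter), giving an estimate of 9.33 with a range of 9.05 to 9.6.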

Compound 4, acid dissociation constant: 9.28
Compound 4: middle estimate off by 0.05 log units, on the high side; the measured number falls inside the stated range.
By their numbers in this assay, from the lowest: compounds 1, 4, 2 and 3 (each within the scatter of the next).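

In this assay, shifting the methoxy group on the phenoxy ring gives no change at the digits printed from compound 1 to compound 4 (within the scatter), so this change to the aryl ether leaves the read-out within the scatter. Returning to an aryl ether from cyclohexyl gives a number 0.19 log units lower from compound 3 to compound 4 (within the scatter), which means that two methoxyphenoxy isomers now sit within the scatter of the cyclohexyl compound. Neither kind of change at this position therefore gives a step beyond the scatter.

On these data alone, whether an amine or a carboxylic acid at this carbon would shift the number remains open. No available evidence bears on the cause of this flat read-out.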